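The source may hold more compounds than are shown below. What is called first, only, known or untested is meant among the compounds shown, and "the series" means these compounds.

Of the compounds shown here, three have been measured in an assay on MDA-MB-231 cells for binding affinity to C-X-C chemokine receptor type 4 (Homo sapiens), read by fluorescence and microscopy, with stated times of 10 min and 30 min; a lower number here means that less compound is needed, a higher number that more compound is needed for the effect. Compound 1 `O=C(NCc1ccc(CNS(=O)(=O)c2cccnc2)cc1)c1ccc(F)cc1` gives 1000 nM, compound 2 `O=C(NCc1ccc(CNS(=O)(=O)c2cccc3ccccc23)cc1)c1ccc(F)cc1` gives 1000 nM, and compound 3 `O=C(NCc1ccc(CNS(=O)(=O)c2ccc(Cl)cc2)cc1)c1ccc(F)cc1` gives 100 nM, the lowest of the three numbers. The steps of a 10-fold lower number from compound 1 to compound 3 (1.00 log units; beyond the scatter) and a 10-fold lower number from compound 2 to compound 3 (1.00 log units; beyond the scatter) both lie beyond the scatter, whereas no change at the digits printed from compound 1 to compound 2 (within the scatter). Compound 4 `O=C(NCc1ccc(CNS(=O)(=O)c2ccccc2F)cc1)c1ccc(F)cc1` differs from compound 3 only on the sulfonyl sulfur: 2-fluorophenyl in place of 4-chlorophenyl on a sulfonyl sulfur. Among the compounds with values here, no measured step swaps one halogen-bearing phenyl for another, so the two steps into compound 3 bear on this change only indirectly, showing that the group on the sulfonyl sulfur can shift this assay by a modest amount in either direction. For compound 4 a moderately higher number than compound 3 is expected, a 3.0-fold higher number from compound 3 to compound 4 (0.48 log units; beyond the scatter). The estimate for compound 4 in this assay is 300 nM, with a range from 100 nM to 1000 nM.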

Compound 4, effective concentration (reported as EC, without a stated level of effect): 10 nM
The estimate for compound 4 lay 30-fold (1.48 log units) above the measured number, and the stated range ends above it.
By their numbers in this assay, from the lowest: compound 4; then compound 3; then compounds 1 and 2 (each within the scatter of the next).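

Within the data shown here, on the sulfonyl sulfur, 2-fluorophenyl gives the lowest number so far in this assay, and exchanging one halogen-bearing phenyl for another proves enough to move it, with a 10-fold lower number from compound 3 to compound 4 (1.00 log units; beyond the scatter). The span at this position widens to a 100-fold lower number from compound 2 to compound 4 (2.00 log units; beyond the scatter) and a 100-fold lower number from compound 1 to compound 4 (2.00 log units; beyond the scatter). No measurement at hand explains the step. Still open, as far as these compounds go, is whether the change follows the halogen or its ring position, which 2-chlorophenyl and 4-fluorophenyl on the sulfonyl sulfur would separate. Also open, from the compounds shown here alone, is how 2-methoxyphenyl compares with 2-fluorophenyl there.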